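Replacing tert-Butyl with 3-Iodophenyl on the Amide Nitrogen

The source may hold more compounds than are shown below. What is called first, only, known or untested is meant among the compounds shown, and "the series" means these compounds.

Compound 1 `CC(C)(C)NC(=O)CCc1cccc2c1B(O)OC2`: > 100000 nM
Compound 2 `COc1ccc(NC(=O)CCc2cccc3c2B(O)OC3)cc1`: 1700 nM
Compound 3 `CC(C)(C)OC(=O)Nc1ccc(NC(=O)CCc2cccc3c2B(O)OC3)cc1`: 24000 nM

In a functional assay on HCT-116 cells (Homo sapiens) for antiproliferative activity, read by MTT assay, with a stated time of 72 h (on this read-out higher numbers stand for weaker inhibition and lower numbers for stronger inhibition), compound 1 gives > 100000 nM, which is a limit of this assay and not a number (the limit of > 100000 nM in this assay, at which 1 of the 3 values shown sits). Within the data shown here, compound 2 gives 1700 nM and compound 3 gives 24000 nM, and a 14-fold higher number from compound 2 to compound 3 (1.15 log units; beyond the scatter) is the only measured step between two numbers. Compound 4 `O=C(CCc1cccc2c1B(O)OC2)Nc1cccc(I)c1` differs from compound 1 in one place: 3-iodophenyl in place of tert-butyl on an amide-type nitrogen. Among the measured compounds shown here, no measured step makes this change directly; the values of compound 2 and compound 3 show that amides bearing an aryl group on the nitrogen give numbers, while compound 1 sits at the limit. For compound 4 a large decrease in number is expected, an at least 33-fold lower number from compound 1 to compound 4 (1.52 log units; beyond the scatter), with its size uncertain. Compound 4 is estimated at 3000 nM, between 800 nM and 30000 nM.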

Compound 4, half-maximal inhibitory concentration: 2300 nM
The estimate for compound 4 lay 1.3-fold (0.12 log units) above the measured number; the measured number falls inside the stated range.
By their numbers in this assay, from the lowest: compounds 2 and 4 (each within the scatter of the next); then compound 3. At a limit, above all of these: compound 1.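

In this assay, 3-iodophenyl on the amide-type nitrogen gives the first direct step away from tert-butyl on the shared core: an at least 43-fold lower number from compound 1 to compound 4 (1.63 log units; beyond the scatter). The value of compound 1 is a limit and not a number, so this step gives only a bound and its full size remains unknown: the limit of > 100000 nM in this assay, at which 1 of the 4 values shown sits.

The compounds shown leave open whether the ring or the iodine accounts for the step, since an unsubstituted phenyl on that nitrogen is not among them. They also leave open how a benzyl group or a longer alkyl chain would read in this assay.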